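Series notes: step from compound 1 to compound 4

The source may report more compounds than this note shows. Statements on the series, on what has been measured and on what is new or still open speak of the compounds shown alone.

For the measured compounds named here, compound 1 `O=C(Nc1ccc(S(=O)(=O)Nc2ccccc2)cc1)c1cc(F)c(Cl)cc1F` is the only member of the series with a number in a functional assay on HEK293 cells for agonist activity at probable G-protein coupled receptor 27 (Homo sapiens), read by a luciferase reporter and beta-arrestin recruitment, with a stated time of 10 min; on this read-out higher numbers stand for larger maximal responses and lower numbers for smaller maximal responses. In this assay compound 1 gives 37%, a partial response relative to the control. Two further members carry no result. Compound 2 `O=C(Nc1ccc(S(=O)(=O)NCc2ccccc2)cc1)c1ccc(Cl)cc1Cl` stands at "not determined" (no result reported) in this assay, and compound 3 `COc1ccc(NS(=O)(=O)c2ccc(NC(=O)c3ccc(Cl)cc3Cl)cc2)cc1` likewise at "not determined" (no result reported). Going by the values given here, no two measured compounds differ in a single place, so no step within the data can serve as a yardstick.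

Compound 4 `O=C(Nc1ccc(S(=O)(=O)Nc2ccccc2)cc1)c1ccc(Br)cc1F` is the next compound to be tested. It differs from compound 1 as follows: 4-bromo-2-fluorophenyl in place of 4-chloro-2,5-difluorophenyl on a carbonyl carbon. The shared core and the carbonyl attachment are unchanged. Among the compounds with values here, with no comparable pair in hand, the expected step in this assay is small, a number 2 percentage points lower from compound 1 to compound 4 (within the scatter), and not beyond the usual scatter. On that basis compound 4 is estimated to reach 35% in this assay, with a range from 15% to 60%.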

Compound 4, largest response reached (Emax), in percent of the reference or control that the assay uses: 67%
The estimate for compound 4 lay 32 percentage points below the measured number, and the stated range ends below it.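

In this assay, the aryl group on the carbonyl carbon proves to be a position that responds: 4-bromo-2-fluorophenyl in place of 4-chloro-2,5-difluorophenyl gives a number 30 percentage points higher from compound 1 to compound 4 (beyond the scatter), the first step the series allows to be read. With the shared core unchanged, a swap confined to the halogens on this ring is enough to shift the maximal response. The data at hand offer no explanation for this step.

The change swaps chlorine for bromine and also removes one fluorine, so this single step cannot show which of the two carries the shift. Also open, as far as these compounds go, is how the response would go with a nitrile, a trifluoromethyl group or an amine in place of the bromine on this ring.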